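Triazole substituent change: cyclopropyl to 2-hydroxyethyl

This account rests on a few compounds, and the source may have more. Where it says the series, first, only, none or still open, it means among the compounds named here.

In a functional assay on CFPAC-1 cells (Homo sapiens) for antiproliferative activity, read by MTT assay, with a stated time of 72 h (a lower number here means a stronger inhibitor, a higher number a weaker inhibitor), compound 1 `CCCCCc1ccc(-c2cn(C[C@H](O)[C@H]3OC(=O)C(OCc4ccccc4)=C3OCc3ccccc3)nn2)cc1` gives 9890 nM, while compound 2 `O=C1O[C@H]([C@@H](O)Cn2cc(C3CC3)nn2)C(OCc2ccccc2)=C1OCc1ccccc1` gives 47700 nM, the higher of the two numbers. For the measured compounds named here, the single measured step, a 4.8-fold higher number from compound 1 to compound 2 (0.68 log units; beyond the scatter), concerned the same aromatic carbon. Compound 3 `O=C1O[C@H]([C@@H](O)Cn2cc(CCO)nn2)C(OCc2ccccc2)=C1OCc1ccccc1` differs from compound 2 by 2-hydroxyethyl in place of cyclopropyl on an aromatic carbon. Going by the values given here, no measured step involves 2-hydroxyethyl, so that one step serves only as a rough guide to how strongly this aromatic carbon moves the number; a modest step upward, or none beyond the scatter, is expected. Compound 3 is estimated at 65000 nM, with a range of 25000 nM to 170000 nM. That estimate corresponds to an expected step of a 1.4-fold higher number from compound 2 to compound 3 (0.13 log units; within the scatter).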

Compound 3, half-maximal inhibitory concentration: > 100000 nM
Compound 3 was reported as a limit; the forecaster's own chance of this, stated with the estimate: 25%; at least 1.5-fold (0.18 log units) between middle value and limit.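

In this assay compound 3 gives > 100000 nM, a limit of the assay and not a number. At equal heavy-atom count, 2-hydroxyethyl in place of cyclopropyl gives an at least 2.0-fold higher number from compound 2 to compound 3 (0.32 log units; beyond the scatter), so this aromatic carbon responds to more than group size. Against 4-pentylphenyl, the same group gives an at least 10-fold higher number from compound 1 to compound 3 (1.00 log units; beyond the scatter).

Going by these compounds, the true size of both new steps stays open, and 2-hydroxyethyl alone cannot separate the hydroxyl from the loss of the ring. An n-propyl chain, an amine or a carboxylic acid on this carbon would help to separate them.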